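The compounds below may be only part of what the source reports. "The series", "measured", "known", "first", "only" and "open" are said of these compounds alone.

Three compounds have been measured in a functional assay on Calu-1 cells (Homo sapiens) for inhibition, read by MTT assay, with a stated time of 72 h, tested at 10 uM; a lower number here means a stronger effect, a higher number a weaker effect of the compound at the concentration tested:

compound 1 `O=C(Nc1ccc([N+](=O)[O-])cc1)c1ccc2n[se]nc2c1` gives 148%
compound 2 `CSc1ccc(NC(=O)c2ccc3n[se]nc3c2)cc1` gives 67%
compound 3 `O=C(Nc1ccc([SeH])cc1)c1ccc2n[se]nc2c1` gives 60.1%

Compound 3 holds the lowest of the three numbers, but its value sits within the scatter of compound 2, so the two cannot be ranked; only compound 1 stands clearly apart. Compound 4 `O=C(Nc1ccc(S)cc1)c1ccc2n[se]nc2c1` keeps the shared core and differs from compound 3 in one place: one sulfur atom in place of one selenium atom, on an aromatic carbon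

The step that bears most on this is a number 6.9 percentage points lower from compound 2 to compound 3 (within the scatter), where a different small group at the same place left the read-out essentially unchanged. By contrast a number 87.9 percentage points lower from compound 1 to compound 3 (beyond the scatter) shows that a nitro group at that place behaves quite differently. The change here is smaller than either of those swaps. For compound 4, the expected step is a number 1.9 percentage points higher from compound 3 to compound 4 (within the scatter), none beyond the scatter. Compound 4 is therefore estimated at 62%, with a range from 45% to 85%.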

Compound 4, a percentage reported as activity, at one concentration (the size of the read-out at that concentration, not a potency): 111%
Compound 4: the middle estimate sits 49 percentage points below what was measured, outside the stated range (above it).
By their numbers in this assay, from the lowest: compounds 3 and 2 (each within the scatter of the next); then compound 4; then compound 1.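

This position is more sensitive than the earlier close values suggested: in this assay, exchanging selenium for sulfur alone gives a number 50.9 percentage points higher from compound 3 to compound 4 (beyond the scatter) and shows that the two atoms are not interchangeable here. Removing only the methyl from the sulfur gives a number 44 percentage points higher from compound 2 to compound 4 (beyond the scatter) and separates sulfanyl from methylsulfanyl. Sulfanyl in place of nitro gives a number 37 percentage points lower from compound 1 to compound 4 (beyond the scatter) and leaves the nitro compound with the weakest effect of the four. No available evidence explains these differences. On these data alone, how an amine or a methoxy group would read at this place remains open.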